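Swapping a methoxy for fluoro at the assay limit

This account rests on a few compounds, and the source may have more. Where it says the series, first, only, none or still open, it means among the compounds named here.

Compound 1 `CCOC(=O)c1c(-c2cccc(-c3ccccc3)c2)[nH]c2cc(OC)c(OC)cc2c1=O`: > 21500 nM (a limit)
Compound 2 `CCOC(=O)c1c(-c2cccc(OC)c2)[nH]c2cc(OC)c(OC)cc2c1=O`: > 21500 nM (a limit)
Compound 3 `CCOC(=O)c1c(-c2cccc(OC)c2)[nH]c2cc(Cl)c(OC)cc2c1=O`: > 21500 nM (a limit)

In an ADME assay on Raji cells (Homo sapiens) for cytotoxicity, read by luminescence, with a stated time of 72 h (a higher number here means that more compound is needed for the effect, a lower number that less compound is needed), compound 2 stands at > 21500 nM and that is a limit of the assay, not a number. It has no readable position among its neighbours, since the record shows the limit of > 21500 nM in this assay, at which 3 of the 3 values shown sit, and offers no numerical value at all.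

Compound 4 `CCOC(=O)c1c(-c2cccc(OC)c2)[nH]c2cc(OC)c(F)cc2c1=O` differs from compound 2 by a single change: fluoro in place of methoxy on an aromatic carbon. This is fluoro in place of methoxy on an aromatic carbon, ortho to a methoxy group.

The nearest measured evidence is a step that the two limits leave unreadable from compound 2 to compound 3 for chloro in place of methoxy on an aromatic carbon, although that change falls on the other methoxy group of compound 2. Further off lies a step that the two limits leave unreadable from compound 1 to compound 2 for methoxy in place of phenyl on an aromatic carbon. Neither gives a size to carry over, and both pairs end at the same limit. No step beyond the scatter is therefore expected in this assay in either direction.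

For compound 4 the expected step is a step that the limit leaves unreadable from compound 2 to compound 4 and it is a nominal estimate only. The estimate for compound 4 is 25000 nM with an expected range from 12000 nM to 50000 nM and a report as a limit is the likeliest outcome.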

Compound 4, half-maximal effective concentration: > 21500 nM
Compound 4: no number, only a limit; the forecaster's own chance of this, stated with the estimate: 85%; the middle value does not contradict the limit.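

In this assay compound 4 gives > 21500 nM, which is a limit and not a number. Compound 2 carries the same limit, and no step can be read between compound 2 and compound 4. The compounds shown leave open how far each of them lies from that limit, and whether fluoro and methoxy differ here at all.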